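This account rests on a few compounds, and the source may have more. Where it says the series, first, only, none or still open, it means among the compounds named here.

Three compounds have readings in a functional assay on HeLa cells (Homo sapiens) for inhibition, with a stated time of 48 h, tested at 50 uM; a lower number here means less inhibition of growth, a higher number more inhibition of growth at the concentration tested: compound 1 (`C=C[C@@](C)(/C=C/c1ccc(OC(=O)CCCCCCCCCCCCCCC)cc1)CCC=C(C)C`) gives 51%, compound 2 (`C=C[C@@](C)(/C=C/c1ccc(O)c(N)c1)CCC=C(C)C`) gives 48% and compound 3 (`CC[C@](C)(CCCC(C)C)CCc1ccc(O)c(I)c1`) gives 43%. Compound 3 therefore lies within the scatter of both other compounds, and these numbers separate none of the three. Compound 4 (`CC[C@](C)(CCCC(C)C)CCc1ccc(O)cc1`) differs from compound 3 by a single change: hydrogen in place of iodo on an aromatic carbon. This places hydrogen in place of iodo on an aromatic carbon, ortho to a hydroxy group. Among the compounds with values here, no measured pair isolates this change in this assay, so no shift beyond the scatter is expected in either direction. The expected step of a number 1 percentage points lower from compound 3 to compound 4 (within the scatter) is correspondingly small. Compound 4 is estimated at 42%, within an expected range of 27% to 57%.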

Compound 4, percent growth inhibition at one concentration: 42%
Estimate against measurement, compound 4: no gap at the digits printed; the range from low to high includes it.
By their numbers in this assay, from the lowest: compounds 4, 3, 2 and 1 (each within the scatter of the next).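

Within the data shown here, the first matched pair, hydrogen in place of iodo on an aromatic carbon ortho to a hydroxy group, gives in this assay a step of a number 1 percentage points lower from compound 3 to compound 4 (within the scatter). At this position, therefore, the reading does not separate iodo from hydrogen at the tested concentration. Nothing available accounts for this result.

As far as these compounds go, whether a carboxylic acid or a methoxy group at the same position would shift the reading beyond the scatter remains open. So does whether the same swap would give a similar step on the core of compound 1 or compound 2.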